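Removing the Cyano Group from Compound 3

A few compounds are considered here, and "the series" means these few. Any claim that something is new, unique, unknown or untested is made for them only; others in the source may bear on it.

Compound 1 `CC1=C(c2cccc(F)c2)C(c2ccc(OC[C@H](C)N3CC[C@@H](C)C3)cc2)Oc2ccc(O)cc21`: 1 nM
Compound 2 `CC1=C(c2cccc(O)c2)C(c2ccc(OC[C@@H](C)N3CC[C@H](C)C3)cc2)Oc2ccc(O)cc21`: 0.2 nM
Compound 3 `CC1=C(c2cccc(C#N)c2)C(c2ccc(OC[C@H](C)N3CC[C@@H](C)C3)cc2)Oc2ccc(O)cc21`: 2.6 nM

These three compounds share one core and differ only in a single group on one aromatic ring. In a functional assay on MCF7 cells (Homo sapiens) for antiproliferative activity, read by CellTiter-Glo, with a stated time of 5 days (a lower number here means a stronger inhibitor, a higher number a weaker inhibitor), compound 3 gives the highest number of the three, with compound 1 nearest and compound 2 furthest. Compound 4 `CC1=C(c2ccccc2)C(c2ccc(OC[C@H](C)N3CC[C@@H](C)C3)cc2)Oc2ccc(O)cc21` carries the change (hydrogen in place of cyano on an aromatic carbon). Going by the values given here, one measured step bears on it: a 2.6-fold higher number from compound 1 to compound 3 (0.41 log units; beyond the scatter), in which the cyano group goes with the higher number. Among the compounds with values here, no measured step leaves hydrogen in place of a group, so the size of the coming step is uncertain, but a modest move toward a lower number is expected, roughly a 2.2-fold lower number from compound 3 to compound 4 (0.34 log units; beyond the scatter). Compound 4 is therefore estimated at 1.2 nM, with a range from 0.4 nM to 4 nM.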

Compound 4, half-maximal inhibitory concentration: 0.4 nM
Beside the measured number, compound 4's estimate is 3.0-fold (0.48 log units) above it; measured number inside the range.
By their numbers in this assay, from the lowest: compounds 2 and 4 (each within the scatter of the next); then compound 1; then compound 3.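

Replacing cyano with hydrogen lowers the number (a 6.5-fold lower number from compound 3 to compound 4 (0.81 log units; beyond the scatter)), and replacing fluoro with hydrogen lowers it too (a 2.5-fold lower number from compound 1 to compound 4 (0.40 log units; beyond the scatter)). The earlier step only ranked cyano against fluoro, whereas these steps show that both groups give a higher number than the unsubstituted phenyl in this series. Nothing available explains these shifts.

Going by these compounds, it remains open whether any group at this place can give a lower number than hydrogen, and a methoxy group, a chlorine atom or an amine would each test that.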